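The source may report more compounds than this note shows. Statements on the series, on what has been measured and on what is new or still open speak of the compounds shown alone.

Compound 1 `CN(Cc1ccccc1OCCC[C@@H]1C[C@H]1C(=O)O)C(=O)c1ccc(-c2ccco2)cc1`: 3.5 h
Compound 2 `C/C(=C\C(=O)O)CCCOc1ccccc1CN(C)C(=O)c1ccc(-c2ccco2)cc1`: 1.6 h

Among the measured compounds shown here, in an ADME assay on the whole organism (strain CD-1) for metabolic stability, with Mus musculus as the target, at a dose of 3 mg/kg by the intravenous route (on this read-out lower numbers stand for a shorter-lived compound and higher numbers for a longer-lived compound), compound 2 gives 1.6 h, the lower of the two numbers so far, and compound 1 gives 3.5 h. Compound 3 `C/C(=C\COc1ccccc1CN(C)C(=O)c1ccc(-c2ccco2)cc1)CCC(=O)O` has the same atoms as compound 2, joined differently: 4-carboxy-2-methylbut-1-en-1-yl in place of 4-carboxy-3-methylbut-3-en-1-yl on a saturated chain carbon bound to an oxygen on an aromatic ring. The change sits on a saturated chain carbon bound to an oxygen on an aromatic ring, and neither the group that leaves nor the one that enters has a ring.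

For the measured compounds named here, only one measured step bears on this: a 2.2-fold lower number from compound 1 to compound 2 (0.34 log units; beyond the scatter). It is modest, though beyond the scatter, and it replaced 2-carboxycyclopropyl with 2-carboxy-1-methylethenyl, so it is only a loose guide to a rearrangement within an open chain. Going by the values given here, no measured pair shows this particular change, so the starting point is compound 2 at 1.6 h, and no clear move in either direction is expected. The expected step is a 1.1-fold higher number from compound 2 to compound 3 (0.05 log units; within the scatter), which would stay within the scatter. Compound 3 is estimated at 1.8 h, with an expected range of 0.8 h to 3.8 h.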

Compound 3, half-life: 2.3 h
Compound 3: middle estimate off by 1.3-fold (0.11 log units), on the low side, and the stated range covers the measured number.
By their numbers in this assay, from the lowest: compounds 2, 3 and 1 (each within the scatter of the next, the first and the last beyond it).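

Within this assay, the atoms of the open chain on the saturated carbon bound to the aromatic oxygen can be rearranged without a readable effect: replacing 4-carboxy-3-methylbut-3-en-1-yl with 4-carboxy-2-methylbut-1-en-1-yl gives a 1.4-fold higher number from compound 2 to compound 3 (0.16 log units; within the scatter). Among the compounds shown here, this is the first comparison here in which both chains are open and made of the same atoms, so it isolates the placement of the double bond, the methyl group and the carboxylic acid along the chain. The comparison with the ring-bearing chain gives a 1.5-fold lower number from compound 1 to compound 3 (0.18 log units; within the scatter), so compound 3 cannot be separated from either neighbour, even though the other listed comparison gives a 2.2-fold lower number from compound 1 to compound 2 (0.34 log units; beyond the scatter).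

As far as these compounds go, whether a longer chain, or a tetrazole in place of the carboxylic acid, would keep the half-life in this same range remains open, as these three compounds differ only in the chain and all keep the acid. Nothing available here explains the half-lives of these three chains.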